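A few compounds are considered here, and "the series" means these few. Any claim that something is new, unique, unknown or untested is made for them only; others in the source may bear on it.

Measured compounds in a functional assay on cells (T-cell, Homo sapiens) for inhibition; a lower number here means a stronger inhibitor, a higher number a weaker inhibitor:
- compound 1 `COc1ccc(-c2cnc3nc(N)nc(N4CCN(C(=O)NCc5ccccc5)CC4)c3n2)cc1OC`: 18 nM
- compound 2 `COc1ccc(-c2cnc3nc(N)nc(NCc4ccccc4)c3n2)cc1OC`: 13000 nM
- compound 3 `COc1ccc(-c2cnc3nc(N)nc(OC(C)C)c3n2)cc1OC`: 400 nM

Compound 1 stands lowest of the three numbers. Its nearest neighbour is compound 3, and compound 2 lies furthest away. Going by the values given here, the one step between measured compounds that differ in one place runs from compound 2 to compound 3, where an isopropoxy replaces a benzylamino on an aromatic carbon: a 33-fold lower number from compound 2 to compound 3 (1.51 log units; beyond the scatter).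

Compound 4 `COc1ccc(-c2cnc3nc(N)nc(N4CCN(c5ccc(C)cc5)CC4)c3n2)cc1OC` differs from compound 1 only at the piperazine ring: 4-methylphenyl in place of benzylcarbamoyl on an amine nitrogen in a ring. Among the compounds with values here, no measured step touches this amine nitrogen in a ring, so the step from compound 2 to compound 3 bears on it only loosely, by showing that exchanges at the shared core can move the number by a large amount. The benzylcarbamoyl that leaves carries one hydrogen-bond donor and one acceptor; the 4-methylphenyl that enters carries none. Within the data shown here, with no direct precedent, a moderate weakening seems the likeliest outcome, though a change within the scatter cannot be excluded.

Compound 4 is expected to give 80 nM, in a range from 10 nM to 600 nM. This estimate means an expected step of a 4.4-fold higher number from compound 1 to compound 4 (0.65 log units; beyond the scatter).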

Compound 4, half-maximal inhibitory concentration: 300 nM
Beside the measured number, compound 4's estimate is 3.8-fold (0.57 log units) below it; measured number inside the range.
By their numbers in this assay, from the lowest: compound 1; then compounds 4 and 3 (each within the scatter of the next); then compound 2.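

In this assay, going by these compounds alone, the one direct reading at the amine nitrogen in a ring is a 17-fold higher number from compound 1 to compound 4 (1.22 log units; beyond the scatter), with 4-methylphenyl in place of benzylcarbamoyl. The group on this nitrogen therefore matters greatly to the number, and a six-membered aromatic ring of carbon, present in both groups, does not by itself preserve the level of compound 1. The step changes the heavy-atom count and removes a hydrogen-bond donor and acceptor together, and no measurement available here accounts for the loss.

Within the data shown here, it remains open which part of benzylcarbamoyl matters, since the single step does not separate its carbonyl, its amide hydrogen and its chain to the aromatic ring. A benzoyl, a methylcarbamoyl or a plain phenyl on the same nitrogen would help to tell these parts apart.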